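The compounds below may be only part of what the source reports. "The series", "measured", "known", "first", "only" and "open" are said of these compounds alone.

Working notes on the series.

Compound 3 `C=CCc1cc(-c2ccc(C(F)(F)F)cc2)ccc1OC` gives 78800 nM in a functional assay on Lewis lung carcinoma cells (Mus musculus) for antiproliferative activity, read by MTT assay, with a stated time of 24 h; on this read-out higher numbers stand for weaker inhibition and lower numbers for stronger inhibition. Its number is the highest of the three shown so far, but the gaps to its neighbours are within the scatter: compound 2 `C=CCc1cc(-c2ccc(C(F)(F)F)cc2)ccc1O` gives 74800 nM, and compound 1 `C=CCc1cc(-c2ccc(OC)cc2)cc(CC=C)c1O` gives 60300 nM. Going by the values given here, the one measured step that joins two compounds differing in a single place is a 1.1-fold higher number from compound 2 to compound 3 (0.02 log units; within the scatter), a change of methyl in place of hydrogen on an oxygen on an aromatic ring, and it moved nothing beyond the scatter.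

Compound 4 `C=CCc1cc(-c2ccc(NC(C)=O)cc2)ccc1OC` has not yet been measured in this assay. It differs from compound 3 as follows: acetamido in place of trifluoromethyl on an aromatic carbon. Among the compounds with values here, no measured step concerns an exchange at an aromatic carbon of the six-membered aromatic ring of carbon only, para to a large group, so nothing in hand bears directly on this change. The data so far show three compounds with differing substituents on that ring all lying within the scatter of one another, and this assay has thus far been insensitive to such exchanges.

On that basis, compound 4 is expected to give about 70000 nM, with a range from 30000 nM to 160000 nM. For compound 4 the step that this estimate means is expected to be a 1.1-fold lower number from compound 3 to compound 4 (0.05 log units; within the scatter), within the scatter.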

Compound 4, half-maximal inhibitory concentration: 65100 nM
The estimate for compound 4 lay 1.1-fold (0.03 log units) above the measured number; the range from low to high includes it.
By their numbers in this assay, from the lowest: compounds 1, 4, 2 and 3 (each within the scatter of the next).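

In this assay, going by these compounds alone, the exchange of trifluoromethyl for acetamido, on an aromatic carbon of a six-membered aromatic ring of carbon only, para to a large group, gives a 1.2-fold lower number from compound 3 to compound 4 (0.08 log units; within the scatter), so this position now has a direct comparison between two compounds that differ in one place, which the earlier compounds did not supply. The entering acetamido carries a hydrogen-bond donor and a hydrogen-bond acceptor, the leaving trifluoromethyl carries neither, and the heavy-atom count is the same, yet this assay does not separate the two groups beyond the scatter. No measurement in hand bears on why these two groups read alike.

Whether that holds for other groups at this position, such as a free amine, a carboxylic acid or a longer chain in place of the acetamido methyl, is left open by the compounds shown. Within the data shown here, also open is whether acetamido reads the same with hydrogen in place of methyl on the oxygen, as in compound 2, since only one pair of compounds speaks to this exchange.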